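Amide variation on a shared core without measurable inhibition

The compounds below may be only part of what the source reports. "The series", "measured", "known", "first", "only" and "open" are said of these compounds alone.

In a functional assay on MIA PaCa-2 cells (Homo sapiens) for inhibition, read by MTT assay, with a stated time of 3 days (on this read-out lower numbers stand for stronger inhibition and higher numbers for weaker inhibition), the three measured compounds give only limits of the assay:

compound 1, `CCN(CC)C(=O)[C@@H]1CCCN(S(=O)(=O)c2ccc(S(=O)(=O)N(CC)CC)cc2)C1`: > 10000 nM
compound 2, `CCN1CC(NC(=O)[C@@H]2CCCN(S(=O)(=O)c3ccc(S(=O)(=O)N(CC)CC)cc3)C2)C1`: > 10000 nM
compound 3, `CCN(CC)S(=O)(=O)c1ccc(S(=O)(=O)N2CCC[C@@H](C(=O)N3CCN(c4nc(C)no4)CC3)C2)cc1`: > 10000 nM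

Compound 2 therefore stands at the limit, not at a number; its value in this assay is one of the three that sit there, as shown by the limit of > 10000 nM in this assay, at which 3 of the 3 values shown sit. For the measured compounds named here, the same holds for compound 1 and for compound 3, so none of the measured steps can be read: a step that the two limits leave unreadable from compound 1 to compound 2, a step that the two limits leave unreadable from compound 1 to compound 3 and a step that the two limits leave unreadable from compound 2 to compound 3. Compound 4, `CCN(CC)S(=O)(=O)c1ccc(S(=O)(=O)N2CCC[C@@H](C(=O)N[C@H]3CCN(C(=O)OC(C)(C)C)C3)C2)cc1`, differs from compound 2 only at the amide: 1-(tert-butoxycarbonyl)pyrrolidin-3-yl in place of 1-ethylazetidin-3-yl on an amide-type nitrogen. Going by the values given here, no measured step bears on this change with a readable size, since every compound that varies the group on the carbonyl carbon sits at the same limit. Compound 4 is therefore expected to remain at or near that limit, and the step that the limit leaves unreadable from compound 2 to compound 4 is estimated to lie within the scatter. For compound 4 the expected value in this assay is 15000 nM, with a range from 5000 nM to 50000 nM.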

Compound 4, half-maximal inhibitory concentration: > 10000 nM
Compound 4 was reported as a limit; the forecaster's own chance of this, stated with the estimate: 85%; the middle value lies beyond the limit too.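

In this assay compound 4 gives > 10000 nM, a limit of the assay. Compound 2 stands at a limit as well, so no step can be read between compound 2 and compound 4: the limit of > 10000 nM in this assay, at which 4 of the 4 values shown sit.

The compounds shown leave open how compound 1, compound 2, compound 3 and compound 4 would rank in this assay, and whether any amide on the shared core gives measurable inhibition.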